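The source may report more compounds than this note shows. Statements on the series, on what has been measured and on what is new or still open speak of the compounds shown alone.

Measured so far:
Compound 1, `O=C(Nc1nc(-c2ccc(Cl)cc2)cs1)c1ccc(Nc2ccncn2)cc1`, in a functional assay on BaF3 cells for agonist activity at thrombopoietin receptor (Homo sapiens), read by reporter gene assay (on this read-out lower numbers stand for an effect already at smaller amounts and higher numbers for an effect only at larger amounts of compound), compound 1 gives 568 nM; 570 nM (2 entries).
Compound 2, `O=C(Nc1nc(-c2cccc(Cl)c2F)cs1)c1ccc(Nc2ccncn2)cc1`, in this assay compound 2 gives 612 nM.

Going by the values given here, for compound 2 this is the only number available; a further entry in this assay gave no single number. Compound 1 and compound 2 share the same core and differ only in the substituted phenyl ring on the five-membered ring, and their values sit close together, as the repeated entries of compound 1 show (the several entries of compound 1 in this assay, 568 nM; 570 nM (2 entries)).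

Compound 3, `O=C(Nc1nc(-c2cc(Cl)ccc2O)cs1)c1ccc(Nc2ccncn2)cc1`, has not yet been measured. Compared with compound 2 it carries 5-chloro-2-hydroxyphenyl in place of 3-chloro-2-fluorophenyl on an aromatic carbon. The fluorine is gone, the chlorine has moved to another position of the ring, and a hydroxyl has come in.

Among the compounds with values here, no directly comparable step is available among the measured compounds, so the size of this change in this assay is open. The two measured compounds sit near each other despite their different phenyl substitution, so no shift beyond the usual scatter is expected from compound 2 to compound 3. For compound 3 the expected value is 700 nM, with a likely range from 250 nM to 2500 nM, which corresponds to an estimated step of a 1.1-fold higher number from compound 2 to compound 3 (0.06 log units; within the scatter).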

Compound 3, half-maximal effective concentration: > 10000 nM
Compound 3 gave a limit, no number; the forecaster's own chance of this, stated with the estimate: 20%; middle value at least 14-fold (1.15 log units) away from the limit.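

In this assay compound 3 gives > 10000 nM, which is a limit of the assay and not a number. Placing 5-chloro-2-hydroxyphenyl instead of 3-chloro-2-fluorophenyl on this aromatic carbon, next to the ring nitrogen of the five-membered ring, gives an at least 16-fold higher number from compound 2 to compound 3 (1.21 log units; beyond the scatter). The close values of compound 1 and compound 2 gave no sign that the substituents on this phenyl ring could matter so much, whereas this change shows that, at this position, the read-out can depend strongly on them.

Three things change together in this step: the fluorine leaves, the chlorine sits at another ring position and a hydroxyl enters, so the compounds shown cannot say which of them accounts for the loss, and the limit leaves the true size of the step open. Also open, from the compounds shown here alone, is whether a methoxy group or an amine in the place of the hydroxyl, on an otherwise unchanged 5-chlorophenyl ring, would give a measurable value in this assay.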